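A few compounds are considered here, and "the series" means these few. Any claim that something is new, unique, unknown or untested is made for them only; others in the source may bear on it.

Measured in a functional assay on HL-60 cells (Homo sapiens) for antiproliferative activity, with a stated time of 72 h; on this read-out higher numbers stand for weaker inhibition and lower numbers for stronger inhibition:
compound 1 `Nc1ncnn2c([C@@H]3O[C@H](CO)[C@@H](O)[C@H]3O)cc(C#Cc3cccs3)c12`: > 100000 nM (a limit)
compound 2 `Nc1ncnn2c([C@@H]3O[C@H](CO)[C@@H](O)[C@H]3O)cc(C#Cc3ccccc3)c12`: > 100000 nM (a limit)

Compound 2 gives only a limit (> 100000 nM) and no number. Both compounds sit at the same limit (the limit of > 100000 nM in this assay, at which 2 of the 2 values shown sit). Going by the values given here, the one measured step (a step that the two limits leave unreadable from compound 1 to compound 2) changes only the ring on the triple bond and has no readable size.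

Compound 3 `Nc1ncnn2c([C@@H]3O[C@H](CO)[C@@H](O)[C@H]3O)cc(-c3ccsc3)c12` carries thiophen-3-yl in place of 2-phenylethynyl on an aromatic carbon, so the triple bond is gone. Among the compounds with values here, no measured step removes it, and none sizes this change. A shift in this assay towards stronger inhibition is expected, but only tentatively, and a second reading at the limit remains possible. Compound 3 is estimated at 3000 nM (expected range 150 nM to 60000 nM). This estimate means an expected step (an at least 33-fold lower number from compound 2 to compound 3 (1.52 log units; beyond the scatter)) of very uncertain size.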

Compound 3, half-maximal inhibitory concentration: 37300 nM
For compound 3 the middle estimate is 12-fold (1.09 log units) below the measured one; measured number inside the range.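

In this assay, this position gives its first readable number once the triple bond is gone: thiophen-3-yl in place of 2-phenylethynyl gives an at least 2.6-fold lower number from compound 2 to compound 3 (0.42 log units; beyond the scatter), and thiophen-3-yl in place of 2-(thiophen-2-yl)ethynyl gives an at least 2.6-fold lower number from compound 1 to compound 3 (0.42 log units; beyond the scatter). Each of these steps starts from a limit, so it sets only a lower bound on the size of the change. Compound 1 and compound 2 remain at one limit of the assay, and the step between them cannot be read: the limit of > 100000 nM in this assay, at which 2 of the 3 values shown sit.

Compound 3 loses the triple bond and takes a different ring attachment in one change, so the compounds shown do not separate these two parts. Also open, as far as these compounds go, is whether a directly attached phenyl, an amine or a carboxylic acid on this aromatic carbon would shift the number further.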